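Cinnamamide quinazolines: trimethoxyphenyl to methoxyphenyl step

The source may hold more compounds than are shown below. What is called first, only, known or untested is meant among the compounds shown, and "the series" means these compounds.

Measured so far:
compound 1 `COc1cc(/C=C/C(=O)Nc2cc3c(Nc4ccc(F)c(Cl)c4)ncnc3cc2O[C@H]2CCOC2)cc(OC)c1OC`: 20500 nM
compound 2 `COc1cc2ncnc(Nc3ccc(F)c(Cl)c3)c2cc1NC(=O)/C=C/c1ccccc1[N+](=O)[O-]`: 14300 nM
compound 3 `COc1cc(/C=C/C(=O)Nc2cc3c(Nc4ccc(F)c(Cl)c4)ncnc3cc2O[C@H]2CCOC2)cc(OC)c1O`: 26500 nM

All three numbers come from a functional assay on PC-3 cells (Homo sapiens) for cytotoxicity, read by MTT assay, with a stated time of 72 h; on this read-out lower numbers stand for stronger inhibition and higher numbers for weaker inhibition. Compound 1 stands second highest of the three; the gap to compound 3, a 1.3-fold higher number from compound 1 to compound 3 (0.11 log units; within the scatter), lies within the scatter, and compound 2 sits within the scatter of compound 1 as well. Compound 4 `COc1ccc(/C=C/C(=O)Nc2cc3c(Nc4ccc(F)c(Cl)c4)ncnc3cc2O[C@H]2CCOC2)cc1` differs from compound 1 by 4-methoxyphenyl in place of 3,4,5-trimethoxyphenyl on a double-bonded chain carbon bound to a double-bonded chain carbon. Within the data shown here, no measured step touches this ring, so the only guide is that the one step seen, the hydrogen in place of methyl, moved nothing. For compound 4 the expected value in this assay is 18000 nM, with a range of 6000 nM to 55000 nM, which means an expected step of a 1.1-fold lower number from compound 1 to compound 4 (0.06 log units; within the scatter), no direction beyond the scatter.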

Compound 4, half-maximal inhibitory concentration: 2240 nM
Compound 4: middle estimate off by 8.0-fold (0.91 log units), on the high side; measured number below the stated range.
By their numbers in this assay, from the lowest: compound 4; then compounds 2, 1 and 3 (each within the scatter of the next).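

In this assay the place on a double-bonded chain carbon bound to a double-bonded chain carbon proves sensitive to the group it carries: 4-methoxyphenyl gives a 9.2-fold lower number from compound 1 to compound 4 (0.96 log units; beyond the scatter) and also a 12-fold lower number from compound 3 to compound 4 (1.07 log units; beyond the scatter). Among these compounds, the earlier hydrogen in place of methyl stayed within the scatter, so the ring exchange shows a response that the single oxygen change did not. Nothing at hand accounts for this step.

As far as these compounds go, whether one lost methoxy group or both carry the step stays open. Also open, from the compounds shown here alone, is whether an unsubstituted phenyl or a phenyl bearing an amine would hold the number of compound 4.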